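Fluoro for methyl on the aryl ring of compound 1

This account rests on a few compounds, and the source may have more. Where it says the series, first, only, none or still open, it means among the compounds named here.

Working notes on the series. Compound 1 `Cc1cc(OCCCCCCC[N+]23CCN(CC2)CC3)ccc1-n1cc(C(=O)Nc2cc(F)cc(F)c2)c(=O)c2ccc(N(C)C)nc21` in an assay on LX2 cells for inhibition of COL1A1 promoter (Homo sapiens), read by a luciferase reporter, with a stated time of 24 h, tested at 50 uM (a higher number here means a stronger effect of the compound at the concentration tested, a lower number a weaker effect), gives "not active" (no number reported), with no number reported for it, so on the numbers shown compound 1 stands without a value against the measured pair. Compound 2 `Cc1cc(-n2cc(C(=O)Nc3cc(F)cc(F)c3)c(=O)c3ccc(N(C)C)nc32)ccc1OCCCCCCC[N+]12CCN(CC1)CC2` in this assay gives 20.8%. Compound 3 `CN(C)c1ccc2c(=O)c(C(=O)Nc3cc(F)cc(F)c3)cn(-c3ccc(OCCCCCCC[N+]45CCN(CC4)CC5)c(Cl)c3)c2n1` in this assay gives 20.5%; the step of a number 0.3 percentage points lower from compound 2 to compound 3 (within the scatter) is within the scatter, so exchanging methyl for a halogen on that aromatic carbon left the read-out unchanged. Compound 4 `CN(C)c1ccc2c(=O)c(C(=O)Nc3cc(F)cc(F)c3)cn(-c3ccc(OCCCCCCC[N+]45CCN(CC4)CC5)cc3F)c2n1` differs from compound 1 as follows: fluoro in place of methyl on an aromatic carbon. Among the measured compounds shown here, no measured step covers this exact change; the only related step is a number 0.3 percentage points lower from compound 2 to compound 3 (within the scatter), a methyl-to-halogen exchange that moved nothing beyond the scatter. Hence no step beyond the scatter is expected in this assay in either direction, and compound 4 is expected to sit near compound 1, which itself gave no number. Compound 4 is estimated at 10%, within a range from 0% to 25%.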

Compound 4, a percentage reported as inhibition, at one concentration (the size of the read-out at that concentration, not a potency): 42.4%
Compound 4: middle estimate off by 32.4 percentage points, on the low side, and the stated range ends below it.
By their numbers in this assay, from the lowest: compounds 3 and 2 (each within the scatter of the next); then compound 4.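

In this assay, among the compounds shown here, compound 1 gives "not active" (no number reported) and so no step to compound 4 can be read. The compounds shown leave open how fluoro compares with methyl on this aromatic carbon. No measured evidence bears on the result.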